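From Carboxy Group to Benzyl Ester Side Chain

The source may hold more compounds than are shown below. What is called first, only, known or untested is meant among the compounds shown, and "the series" means these compounds.

In a functional assay on A549 cells (Homo sapiens) for cytotoxicity, read by colorimetric assay and MTT assay (a higher number here means a weaker inhibitor, a lower number a stronger inhibitor), compound 1 (`CCN(CC)C(=O)Cn1c(=O)c(-c2ccc(OC)cc2)cc2c(OC)cc(OC)cc21`) gives 10000 nM. Compound 2 (`COc1ccc(-c2cc3c(OC)cc(OC)cc3n(CC(=O)OCc3ccccc3)c2=O)cc1`) gives 10000 nM. Compound 3 (`COc1ccc(-c2cc3c(OC)cc(OC)cc3n(CC(=O)O)c2=O)cc1`) gives 10000 nM, which places it level with the other two.

Compound 4 (`COc1ccc(-c2cc3c(OC)cc(OC)cc3n(CCC(=O)OCc3ccccc3)c2=O)cc1`) keeps the shared core and differs from compound 3 as follows: (benzyloxycarbonyl)methyl in place of carboxy on a saturated chain carbon bound to an aromatic nitrogen. Thus (benzyloxycarbonyl)methyl stands in place of carboxy on a saturated chain carbon bound to an aromatic nitrogen.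

The measured steps show no change at the digits printed from compound 2 to compound 3 (within the scatter) when hydrogen replaces benzyl, no change at the digits printed from compound 1 to compound 3 (within the scatter) when hydroxy replaces diethylamino, and no change at the digits printed from compound 1 to compound 2 (within the scatter) when benzyloxy replaces diethylamino. None of the three compounds carries the entering group, so this evidence is indirect. Even so, these flat steps give no reason to expect a shift in either direction in this assay. The expected result is no change at the digits printed from compound 3 to compound 4 (within the scatter), with no change beyond the scatter. Compound 4 is estimated at 10000 nM, with an expected range of 4000 nM to 20000 nM.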

Compound 4, half-maximal inhibitory concentration: 10000 nM
Compound 4: middle estimate and measured number agree at the digits printed; the range from low to high includes it.
By their numbers in this assay, from the lowest: compounds 1, 2, 3 and 4 (each within the scatter of the next).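

In this assay, the result adds a side chain that carries a six-membered aromatic ring of carbon only on a (benzyloxycarbonyl)methyl group, and there is no change at the digits printed from compound 3 to compound 4 (within the scatter) when this group stands in place of carboxy on a saturated chain carbon bound to an aromatic nitrogen. Ester against ester, there is no change at the digits printed from compound 2 to compound 4 (within the scatter) when (benzyloxycarbonyl)methyl replaces benzyloxycarbonyl at this place, and amide against ester, there is no change at the digits printed from compound 1 to compound 4 (within the scatter) when it replaces diethylcarbamoyl. No measurement shown here accounts for these results.

The compounds shown leave open whether an amine or a still longer chain at this place would give a different value. They also leave open whether any group on this side chain would matter once the methoxy groups on the shared core are replaced.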